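Trading a triazole for a hydroxyl on the side chain

The source may hold more compounds than are shown below. What is called first, only, known or untested is meant among the compounds shown, and "the series" means these compounds.

Compound 1 `Cn1ncc(Cl)c1-c1cc(C(=O)N[C@@H]2CN[C@H](CCn3cncn3)C[C@H]2c2ccc(Cl)c(Cl)c2)oc1Cl`: 4.47 nM
Compound 2 `CNC(=O)C[C@@H]1C[C@@H](c2ccc(F)c(F)c2)[C@H](NC(=O)c2cc(-c3c(Cl)cnn3C)c(Cl)o2)CN1`: 1.37 nM
Compound 3 `O=C(N[C@@H]1CNCC[C@H]1c1ccc(Cl)cc1)c1ccc(-c2ncnc3c2CCC3O)s1`: > 1000 nM

These values come from an assay for inhibition of RAC-alpha serine/threonine-protein kinase (Homo sapiens), read by HTRF, with a stated time of 1 h; on this read-out lower numbers stand for stronger inhibition and higher numbers for weaker inhibition. Of the two numbers shown, compound 1 gives the higher one, and its gap to compound 2 lies beyond the usual scatter of repeated measurements. Compound 3 reaches only the limit of this assay, so its value is not a number.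

Compound 4 `Cn1ncc(Cl)c1-c1cc(C(=O)N[C@@H]2CN[C@H](CCO)C[C@H]2c2ccc(Cl)c(Cl)c2)oc1Cl` has not yet been measured in this assay. It differs from compound 1 in a single place: hydroxy in place of 1H-1,2,4-triazol-1-yl on a saturated chain carbon, two bonds along the chain from a saturated ring carbon. Going by the values given here, no measured pair shows a change of this kind, so the expectation rests on compound 1 alone. The expected step, a 1.8-fold higher number from compound 1 to compound 4 (0.25 log units; within the scatter), is modest and toward a somewhat higher number, but it may well stay within the scatter. Compound 4 is thus expected to give about 8 nM in this assay, between 2.5 nM and 25 nM.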

Compound 4, half-maximal inhibitory concentration: 2.74 nM
Compound 4: the middle estimate sits 2.9-fold (0.47 log units) above what was measured; low and high end bracket the measured number.
By their numbers in this assay, from the lowest: compounds 2, 4 and 1 (each within the scatter of the next, the first and the last beyond it). At a limit, above all of these: compound 3.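

Replacing 1H-1,2,4-triazol-1-yl with hydroxy on this chain gives a 1.6-fold lower number from compound 1 to compound 4 (0.21 log units; within the scatter) in this assay, so the two compounds cannot be told apart. This position therefore accepts hydroxy, with 1 heavy atom and no ring, as well as an aromatic ring of 5 heavy atoms. The data shown give no reason for this tolerance. On these data alone, whether an amine, a carboxylic acid or a longer chain ending in hydroxy would also be accepted at this position remains open.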